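Methoxy on the core carbon: expectation for compound 3

A few compounds are considered here, and "the series" means these few. Any claim that something is new, unique, unknown or untested is made for them only; others in the source may bear on it.

Measured so far:
compound 1, `O=C(Nc1ccc(-c2cnc3cc(N4CCC4)ccn23)cc1)c1ccc([N+](=O)[O-])o1`, gives > 5000 nM in a functional assay on AGS cells (Homo sapiens) for antiproliferative activity, read by CCK-8 assay, with a stated time of 72 h; on this read-out lower numbers stand for stronger inhibition and higher numbers for weaker inhibition; this value is a limit of the assay.
compound 2, `O=C(Nc1ccc(-c2cnc3ccccn23)cc1)c1ccc([N+](=O)[O-])o1`, gives 360 nM in this assay.

Within the data shown here, compound 2 holds the only numeric value; the other entry is the limit (the limit of > 5000 nM in this assay, at which 1 of the 2 values shown sits), at which compound 1 sits. Among the measured compounds shown here, the one measured step, an at least 13-fold lower number from compound 1 to compound 2 (1.14 log units; beyond the scatter), is large and beyond the scatter: removing azetidin-1-yl from that aromatic carbon turns a limit into a number.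

Compound 3, `COc1ccn2c(-c3ccc(NC(=O)c4ccc([N+](=O)[O-])o4)cc3)cnc2c1`, differs from compound 2 by methoxy in place of hydrogen on an aromatic carbon, at the same carbon that carries azetidin-1-yl in compound 1. For the measured compounds named here, the step from compound 1 to compound 2 is the only evidence bearing on this position, and it shows that a group on this carbon weakens activity. Methoxy is a different group from azetidin-1-yl, so the size of the effect need not match, but the direction is expected to be the same: a weaker number for compound 3 than for compound 2.

Compound 3 is therefore estimated at 1200 nM in this assay, with a range of 400 nM to 4000 nM, meaning an expected step of a 3.3-fold higher number from compound 2 to compound 3 (0.52 log units; beyond the scatter).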

Compound 3, half-maximal inhibitory concentration: 720 nM
Compound 3: the middle estimate sits 1.7-fold (0.22 log units) above what was measured; the measured number falls inside the stated range.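

In this assay, methoxy in place of hydrogen on this aromatic carbon gives a 2.0-fold higher number from compound 2 to compound 3 (0.30 log units; within the scatter), so a group on this carbon does not by itself bring the large loss, which the earlier pair could not show. Methoxy in place of azetidin-1-yl at the same carbon gives an at least 6.9-fold lower number from compound 1 to compound 3 (0.84 log units; beyond the scatter), which ties that loss to the azetidin-1-yl group rather than to substitution here in general. Compound 1 stands at a limit and not at a number, so this step and the earlier one are known only as bounds, and their full size cannot be read: the limit of > 5000 nM in this assay, at which 1 of the 3 values shown sits.

With only hydrogen, methoxy and azetidin-1-yl shown on this carbon, it remains open whether a primary amine, a carboxylic acid or a longer alkoxy chain would read like methoxy or like azetidin-1-yl. Two substituents also cannot show which difference between methoxy and azetidin-1-yl matters, and a dimethylamino or pyrrolidin-1-yl group on this carbon would be needed to separate the ring from the amine nitrogen.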